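The source may report more compounds than this note shows. Statements on the series, on what has been measured and on what is new or still open speak of the compounds shown alone.

Measured compounds:
compound 1, `Cc1cc(=O)n(-c2ccccc2OC(F)(F)F)nc1C(=O)Nc1ccc(Oc2ncnc3c2ccn3C)c(F)c1`: > 60000 nM
compound 2, `Cc1cc(=O)n(-c2ccc(Br)cc2F)nc1C(=O)Nc1ccc(Oc2ncnc3c2ccn3C)c(F)c1`: 6670 nM
compound 3, `Cc1ccc(-n2nc(C(=O)Nc3ccc(Oc4ncnc5c4ccn5C)c(F)c3)c(C)cc2=O)cc1`: 50500 nM

In a functional assay on PC-3 cells (Homo sapiens) for cytotoxicity, read by MTT assay, with a stated time of 72 h (a higher number here means a weaker inhibitor, a lower number a stronger inhibitor), compound 3 gives 50500 nM, the higher of the two numbers obtained. Its nearest neighbour is compound 2, with the step of a 7.6-fold higher number from compound 2 to compound 3 (0.88 log units; beyond the scatter). For compound 1 this assay reports only a limit, (the limit of > 60000 nM in this assay, at which 1 of the 3 values shown sits), and no number. The step of an at least 1.1-fold lower number from compound 1 to compound 3 (0.07 log units; that floor lies within the scatter) therefore rests on a limit, as does the step of an at least 8.9-fold lower number from compound 1 to compound 2 (0.95 log units; beyond the scatter).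

Compound 4, `Cc1cc(=O)n(-c2ccccc2Cl)nc1C(=O)Nc1ccc(Oc2ncnc3c2ccn3C)c(F)c1`, differs from compound 3 in one place: 2-chlorophenyl in place of 4-methylphenyl on an aromatic nitrogen. Among the measured compounds shown here, two measured steps bear on this change. Compound 1, whose aryl group is 2-(trifluoromethoxy)phenyl, sits at the limit, and the step from compound 1 to compound 3 left the two within the scatter. Compound 2, whose aryl group is 4-bromo-2-fluorophenyl, stands modestly lower than compound 3. The 2-chlorophenyl of compound 4 shares a halogen with compound 2 and a 2-substitution with compound 1, so the two precedents pull in opposite directions and neither is strong. Compound 4 is therefore expected to give 35000 nM in this assay, within 9000 nM to 90000 nM. That estimate means a step of a 1.4-fold lower number from compound 3 to compound 4 (0.16 log units; within the scatter), expected to stay within the scatter.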

Compound 4, half-maximal inhibitory concentration: > 60000 nM
Compound 4: only a limit was reported; the forecaster's own chance of this, stated with the estimate: 35%; at least 1.7-fold (0.23 log units) between middle value and limit.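

In this assay, compound 4 gives a limit and not a number, and it now sits with compound 1 at that ceiling: the limit of > 60000 nM in this assay, at which 2 of the 4 values shown sit. The change from 4-bromo-2-fluorophenyl to 2-chlorophenyl gives an at least 8.9-fold higher number from compound 2 to compound 4 (0.95 log units; beyond the scatter), which shows that a halogen on this aryl group does not by itself carry the lower number seen with the 4-bromo-2-fluorophenyl group. The change from 4-methylphenyl to 2-chlorophenyl gives only an at least 1.1-fold higher number from compound 3 to compound 4 (0.07 log units; that floor lies within the scatter), so this floor separates these two aryl groups no more than the scatter would, and the step between compound 1 and compound 4 cannot be read, as both are limits.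

The compounds shown do not separate the contribution of the bromine from that of the fluorine in compound 2, as each step replaces the whole aryl group. Going by these compounds, how a plain phenyl group, or a phenyl group carrying an amine or a carboxylic acid, would read in this assay also stays open.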